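Sulfur to Selenium on a Cytotoxicity-Silent Scaffold

This account rests on a few compounds, and the source may have more. Where it says the series, first, only, none or still open, it means among the compounds named here.

The measurements come from an ADME assay on cells (Fibroblast, Homo sapiens) for cytotoxicity, read by MTT assay, with a stated time of 24 h; a lower number here means a stronger inhibitor, a higher number a weaker inhibitor. Compound 2 `COc1ccc(N(CC(=O)NCCCSc2ccccc2)C(=O)/C=C/c2ccccc2)cc1` gives only a limit in this assay, >= 100000 nM, and no number beyond that limit is known for it. Compound 1 `COc1ccc(N(CC(=O)NCCC[Se]c2ccccc2)C(=O)CNC(=O)OC(C)(C)C)cc1` likewise reaches only a limit, >= 100000 nM. Among the measured compounds shown here, both values therefore rest at the same point, namely (the limit of >= 100000 nM in this assay, at which 2 of the 2 values shown sit), so nothing in the data separates the two compounds, and no step between them can be drawn.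

Compound 3 `COc1ccc(N(CC(=O)NCCC[Se]c2ccccc2)C(=O)/C=C/c2ccccc2)cc1` is the compound still to be tested. It differs from compound 2 in one place: a group of 7 heavy atoms (6 carbon, 1 selenium; one six-membered aromatic ring of carbon only) in place of a group of 7 heavy atoms (6 carbon, 1 sulfur; one six-membered aromatic ring of carbon only), on a saturated chain carbon, three bonds along the chain from an amide-type nitrogen. For the measured compounds named here, no measured pair in the data covers a change of this kind, so the size and direction of the step cannot be read from any neighbour. Given that compound 2 sits at the limit, the step expected from compound 2 to compound 3 in this assay is a number no higher from compound 2 to compound 3 (the limit leaves the size open), that is, none that would show beyond the scatter. Compound 3 is accordingly expected at about 100000 nM, with a range from 50000 nM to 200000 nM, most likely reported again only as a limit.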

Compound 3, half-maximal inhibitory concentration: >= 100000 nM
Compound 3 was reported as a limit (the forecaster's own chance of this, stated with the estimate: 75%); the middle value lies on the limit itself.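

Among the compounds shown here, compound 3 ends at the same limit as compound 1 and compound 2, so no step from either of them to compound 3 can be read: the limit of >= 100000 nM in this assay, at which 3 of the 3 values shown sit. What the compounds shown leave open is whether selenium in place of sulfur changes anything in this assay for a compound whose value is a number rather than a limit.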